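This account rests on a few compounds, and the source may have more. Where it says the series, first, only, none or still open, it means among the compounds named here.

Compound 1 `Cc1ccc(-c2ccc3[nH]c(=O)nc(-c4ccccc4)c3c2)cn1` — in an ADME assay on THP-1 cells (Homo sapiens) for cytotoxicity, read by MTT assay, with a stated time of 72 h (on this read-out higher numbers stand for an effect only at larger amounts of compound and lower numbers for an effect already at smaller amounts), compound 1 gives > 50000 nM, a limit.
Compound 2 `O=c1nc(-c2ccccc2)c2cc(-c3ccc(N4CCCC4)nc3)ccc2[nH]1` — compound 2 gives > 50000 nM, a limit.
Compound 3 `O=c1nc(-c2ccccc2)c2ccc(-c3cncnc3)cc2[nH]1` — compound 3 gives > 50000 nM, a limit.

Compound 1 stands at the limit of this assay and has no number of its own. The two further values shown are limits as well. Within the data shown here, the one step between measured compounds, a step that the two limits leave unreadable from compound 1 to compound 2, exchanges methyl for pyrrolidin-1-yl on an aromatic carbon, and its size cannot be read because both ends are limits. The common picture is the limit of > 50000 nM in this assay, at which 3 of the 3 values shown sit.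

Compound 4 `Cc1ccc2[nH]c(=O)nc(-c3ccccc3)c2c1` differs from compound 1 by methyl in place of 6-methylpyridin-3-yl on an aromatic carbon. Among the measured compounds shown here, no measured step with a readable size bears on this change, since the only step available, from compound 1 to compound 2, is unreadable. For the measured compounds named here, because every compound so far sits at the limit (the limit of > 50000 nM in this assay, at which 3 of the 3 values shown sit), no step beyond the scatter is expected in this assay, in either direction. Compound 4 is therefore expected to give about 60000 nM, within a range from 30000 nM to 150000 nM, most likely reported again only as a limit. The expected step from compound 1 to compound 4 is a step that the limit leaves unreadable from compound 1 to compound 4.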

Compound 4, half-maximal effective concentration: > 50000 nM
Compound 4 ended at the assay's limit; the forecaster's own chance of this, stated with the estimate: 85%; the middle value does not contradict the limit.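

No new step can be read: compound 1 and compound 4 both stand at a limit in this assay, so the step between them has no readable size. The compounds shown leave open at what concentration, if any, each would reach a half-maximal effect.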